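The compounds below may be only part of what the source reports. "The series", "measured", "known", "first", "only" and "open" are said of these compounds alone.

Compound 1 `CC(=O)N1CCCN(c2cccc(Nc3nccc(-c4n[nH]c5ccccc45)n3)c2)CC1`: 18 nM
Compound 2 `CC(=O)N1CCN(c2ccc(Nc3nccc(-c4c[nH]c5ccccc45)n3)cc2)CC1`: 33 nM

In a functional assay on MV4-11 cells (Homo sapiens) for antiproliferative activity, read by resazurin assay, with a stated time of 72 h (a higher number here means a weaker inhibitor of growth, a lower number a stronger inhibitor of growth), compound 1 gives 18 nM, and compound 2 gives 33 nM; the two numbers sit within the scatter of each other, so neither can be called the more potent. Within the data shown here, no step between measured compounds connects them, as they differ in more than one place. Compound 3 `CC(=O)N1CCCN(c2cccc(Nc3nccc(-c4c[nH]c5ncccc45)n3)c2)CC1` differs from compound 1 by a group of 9 heavy atoms (7 carbon, 2 nitrogen; one five-membered aromatic ring with 1 hetero atom, one six-membered aromatic ring with 1 hetero atom) in place of a group of 9 heavy atoms (7 carbon, 2 nitrogen; one five-membered aromatic ring with 2 hetero atoms, one six-membered aromatic ring of carbon only), on an aromatic carbon. Among the measured compounds shown here, no measured step in this assay covers this change, so the expectation rests only on compound 1. The step of a 1.4-fold higher number from compound 1 to compound 3 (0.14 log units; within the scatter) is expected to stay within the scatter, with no clear direction. Compound 3 is therefore expected to give 25 nM, with a range from 8 nM to 80 nM.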

Compound 3, concentration for 50% growth inhibition: 20 nM
Compound 3: the middle estimate sits 1.3-fold (0.10 log units) above what was measured; measured number inside the range.
By their numbers in this assay, from the lowest: compounds 1, 3 and 2 (each within the scatter of the next).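

Exchanging the 1H-indazol-3-yl group for a group with the same count of heavy atoms, which carries its second nitrogen in the six-membered aromatic ring instead of the five-membered one, gives a 1.1-fold higher number from compound 1 to compound 3 (0.05 log units; within the scatter) in this assay. At this position, next to the ring nitrogen, moving that nitrogen therefore produces no change that can be read. The two groups have the same counts of hydrogen-bond donors and acceptors, so those counts do not separate them.

On these data alone, whether an amine or a methyl group on the six-membered aromatic ring of the entering group would keep this level of growth inhibition remains open. No measurement shown here bears on the reason for this result.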